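The source may report more compounds than this note shows. Statements on the series, on what has been measured and on what is new or still open speak of the compounds shown alone.

Working notes on the series.

Two compounds share the core of compound 1, `Nc1cc(N)c2nc(-c3ccccc3)c(Oc3ccc(Cl)c(Cl)c3)nc2c1`, and have been measured in a functional assay on SR cells (Homo sapiens) for inhibition, read by sulforhodamine B assay, with a stated time of 48 h; on this read-out lower numbers stand for stronger inhibition of growth and higher numbers for weaker inhibition of growth. Compound 1 gives 33900 nM in this assay. Compound 2, `CCOC(=O)[C@H](CCC(=O)O)NC(=O)c1ccc(Sc2nc3cc(N)cc(N)c3nc2-c2ccccc2)cc1`, gives 7760 nM in this assay. Of the two numbers, compound 1 holds the higher one; compound 2 sits well apart from it, beyond the scatter, on the side of stronger growth inhibition. Compound 2 differs from compound 1 in more than one place, so nothing can be read from that pair about any single change.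

The next compound, compound 3, `Nc1cc(N)c2nc(-c3ccccc3)c(Oc3ccc(F)cc3)nc2c1`, differs from compound 1 in one place only: 4-fluorophenyl in place of 3,4-dichlorophenyl on an oxygen on an aromatic ring. Going by the values given here, no measured pair in the set shows this change, so there is nothing to anchor its size. The expectation is a step of no size beyond the scatter, a 1.2-fold higher number from compound 1 to compound 3 (0.07 log units; within the scatter), from compound 1 to compound 3 in this assay, with the direction left open. Compound 3 is accordingly estimated at 40000 nM in this assay, within a range of 10000 nM to 150000 nM.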

Compound 3, concentration for 50% growth inhibition: 8130 nM
The estimate for compound 3 lay 4.9-fold (0.69 log units) above the measured number; the measured number lies below the stated range.
By their numbers in this assay, from the lowest: compounds 2 and 3 (each within the scatter of the next); then compound 1.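

In this assay, going by these compounds alone, 4-fluorophenyl in place of 3,4-dichlorophenyl on the oxygen gives a 4.2-fold lower number from compound 1 to compound 3 (0.62 log units; beyond the scatter), the first step that can be read at a single place. It shows that the group on this oxygen is not silent: changing it alone moves the number beyond the scatter, towards stronger growth inhibition, although the step is modest. No measurement at hand bears on why the number moves.

This one step removes two chlorine atoms and brings in one fluorine atom, so it leaves open how much of the shift goes with losing the chlorine atoms and how much with gaining the fluorine atom, and whether a plain phenyl on the same oxygen would fall nearer compound 1 or compound 3. Also open, on these data alone, is what a methoxy group, an amine or a carboxylic acid on that ring would do, and whether the same change would give a step of similar size and direction on a sulfur in place of the oxygen.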